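Swapping the amide substituent: from fluorobenzyl to chlorophenyl

A few compounds are considered here, and "the series" means these few. Any claim that something is new, unique, unknown or untested is made for them only; others in the source may bear on it.

Of the compounds shown here, three of a shared core have been tested in a functional assay on A549 cells (Homo sapiens) for inhibition, read by MTT assay, with a stated time of 48 h; on this read-out lower numbers stand for stronger inhibition and higher numbers for weaker inhibition. Compound 1 `COc1cccc(NC(=O)/C=C/c2coc3cc(OC)ccc3c2=O)c1` gives 12800 nM. Compound 2 `COc1ccc2c(=O)c(/C=C/C(=O)NCc3cccc(F)c3)coc2c1` gives 26900 nM, the highest of the two plain numbers. Compound 3 `O=C(/C=C/c1coc2cc(O)ccc2c1=O)NCc1ccc(F)cc1` reaches only the limit of this assay, > 100000 nM, so no number is known for it. Within the data shown here, the one measured step between neighbours, a 2.1-fold higher number from compound 1 to compound 2 (0.32 log units; beyond the scatter), is a modest move towards weaker inhibition.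

Compound 4 `COc1ccc2c(=O)c(/C=C/C(=O)Nc3ccc(Cl)cc3)coc2c1` has not yet been measured. It differs from compound 2 at one place: 4-chlorophenyl in place of 3-fluorobenzyl on an amide-type nitrogen. This is the same site that was changed between compound 1 and compound 2, where an aryl group on the amide nitrogen was replaced by a benzyl group and the number rose modestly. Compound 4 returns to an aryl group directly on that nitrogen, so the expectation is a step of similar size back in the other direction, towards a lower number, though a chlorine on the new ring and a methoxy on the old one make the comparison loose. The step from compound 2 to compound 4 is therefore estimated at a 1.9-fold lower number from compound 2 to compound 4 (0.28 log units; within the scatter). Compound 4 is expected to give about 14000 nM in this assay, within a range from 5000 nM to 45000 nM.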

Compound 4, half-maximal inhibitory concentration: > 100000 nM
Compound 4: only a limit was reported (the forecaster's own chance of this, stated with the estimate: 15%); at least 7.1-fold (0.85 log units) between middle value and limit.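

In this assay compound 4 gives > 100000 nM, which is a limit of the assay and not a number. Among these compounds, this shows that having an aryl group directly on the amide-type nitrogen does not by itself bring back the lower number of compound 1: replacing 3-fluorobenzyl with 4-chlorophenyl gives an at least 3.7-fold higher number from compound 2 to compound 4 (0.57 log units; beyond the scatter), and replacing 3-methoxyphenyl with 4-chlorophenyl gives an at least 7.8-fold higher number from compound 1 to compound 4 (0.89 log units; beyond the scatter), so the identity of the group on this nitrogen matters more than the single step from compound 1 to compound 2 suggested. Both steps give only the smallest possible size of the change, and nothing more can be read at that end of the scale: the limit of > 100000 nM in this assay, at which 2 of the 4 values shown sit.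

The compounds shown do not separate the effect of the chlorine from that of the aryl ring carrying it, and a plain phenyl group on the same nitrogen would help to do so. Also open, going by these compounds, is how a phenyl ring carrying an amine or a carboxylic acid would behave at this position.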